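This account rests on a few compounds, and the source may have more. Where it says the series, first, only, none or still open, it means among the compounds named here.

Measured so far in an assay on membranes from HEK293 cells for displacement of a labelled ligand from Neuronal acetylcholine receptor; alpha3/beta4 (Homo sapiens), with a stated time of 5 min; a lower number here means a stronger inhibitor, a higher number a weaker inhibitor:
compound 1 `CN1CCC[C@H]1[C@@H]1COc2ccc(N)cc2O1`: 19 nM
compound 2 `CN1CCC[C@H]1[C@H]1COc2ccc(N)cc2O1`: 180 nM

Going by the values given here, compound 1 holds the lowest of the two numbers in this assay; its nearest neighbour is compound 2, and the only measured step, a 9.5-fold higher number from compound 1 to compound 2 (0.98 log units; beyond the scatter), is tied to the fact that compounds 1 and 2 differ only in the configuration as drawn and to nothing else.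

Compound 3 `CN1CCC[C@H]1[C@@H]1COc2ccc([N+](=O)[O-])cc2O1` keeps the configuration of compound 1 and differs in one place: nitro in place of amino on an aromatic carbon. Among the compounds with values here, no measured step touches a substituent on the aromatic ring, so the stereochemical step from compound 1 to compound 2 gives no guidance on this change, and no direction can be read from the two numbers at hand. With nothing pointing either way, compound 3 is expected to stay close to compound 1, without a step beyond the scatter. The estimate for compound 3 in this assay is 25 nM, with a range from 6 nM to 110 nM, which means an expected step of a 1.3-fold higher number from compound 1 to compound 3 (0.12 log units; within the scatter).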

Compound 3, inhibition constant: 4500 nM
Compound 3: middle estimate off by 180-fold (2.26 log units), on the low side, outside the stated range (above it).
By their numbers in this assay, from the lowest: compound 1; then compound 2; then compound 3.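

In this assay, the group on this aromatic carbon proves to matter strongly: with the configuration of compound 1 kept, nitro in place of amino gives a 240-fold higher number from compound 1 to compound 3 (2.37 log units; beyond the scatter). That large step exceeds the modest one seen for the configurational change, a 9.5-fold higher number from compound 1 to compound 2 (0.98 log units; beyond the scatter), so among these compounds the substituent change counts for more than the change at the stereocentre. The information at hand offers no explanation for the size of the step with nitro.

This single pair cannot show whether the result reflects the loss of amino or the arrival of nitro, and a methoxy group, an acetamide or plain hydrogen on the same carbon would be needed to separate the two. Going by these compounds, it also remains open whether nitro would have a similar effect in the configuration of compound 2.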